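Acrylamide replacing chloropropyl on the benzylamide carbonyl

The source may hold more compounds than are shown below. What is called first, only, known or untested is meant among the compounds shown, and "the series" means these compounds.

The series shares the tert-butylbenzylamine core. Compound 1 `CC(C)(C)c1ccc(CNC(=O)NCCCCl)cc1` gives 19000 nM in a functional assay on HT-29 cells (Homo sapiens) for antiproliferative activity, with a stated time of 48 h; on this read-out lower numbers stand for stronger inhibition and higher numbers for weaker inhibition. Compound 2 `CC(C)(C)c1ccc(CNC(=O)NC(=O)CCl)cc1` gives 7100 nM in this assay, and the step of a 2.7-fold lower number from compound 1 to compound 2 (0.43 log units; beyond the scatter). Compound 3 `CC(C)(C)c1ccc(CNC(=O)CCCCl)cc1` gives 72000 nM and stands highest of the three numbers: the steps of a 3.8-fold higher number from compound 1 to compound 3 (0.58 log units; beyond the scatter) and a 10-fold higher number from compound 2 to compound 3 (1.01 log units; beyond the scatter) both run to it, the second being the larger.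

Compound 4 `C=CC(=O)NCc1ccc(C(C)(C)C)cc1` differs from compound 3 by vinyl in place of 3-chloropropyl on a carbonyl carbon, a change on the same carbonyl carbon that the steps from compound 1 and compound 2 to compound 3 also touched. Within the data shown here, no measured step exchanges vinyl for 3-chloropropyl, so the direction is inferred only from compound 3 being the weakest point of the series and from every change at this carbonyl having moved the number by a modest to large amount. A lower number than compound 3 is expected, with wide uncertainty, estimated as a 6.0-fold lower number from compound 3 to compound 4 (0.78 log units; beyond the scatter). For compound 4 the expected value in this assay is 12000 nM, within a range of 3000 nM to 50000 nM.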

Compound 4, half-maximal inhibitory concentration: > 100000 nM
Compound 4: a limit, no number; the forecaster's own chance of this, stated with the estimate: 10%; middle value at least 8.3-fold (0.92 log units) from the limit.
By their numbers in this assay, from the lowest: compound 2; then compound 1; then compound 3. At a limit, above all of these: compound 4.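

In this assay compound 4 stands at a limit and not at a number: the limit of > 100000 nM in this assay, at which 1 of the 4 values shown sits. Replacing the (3-chloropropyl)amino and ((chloromethyl)carbonyl)amino groups on the carbonyl carbon with vinyl gives an at least 5.2-fold higher number from compound 1 to compound 4 (0.72 log units; beyond the scatter) and an at least 14-fold higher number from compound 2 to compound 4 (1.14 log units; beyond the scatter), so vinyl does not restore the activity lost in compound 3 and both floors lie beyond the scatter. Only a floor can be read against 3-chloropropyl, an at least 1.3-fold higher number from compound 3 to compound 4 (0.14 log units; that floor lies within the scatter), and it does not separate the two groups on this carbonyl carbon.

As far as these compounds go, the size of the gap between 3-chloropropyl and vinyl remains open, as does the real value of compound 4. Also open, from the compounds shown here alone, is whether a chloromethyl group, a longer chloroalkyl chain or a terminal amine on this carbonyl carbon would read differently, and how vinyl would read on an amino group at the same carbon.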